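Tert-Butyl in Place of Chloro: Growth Inhibition Expected

This account rests on a few compounds, and the source may have more. Where it says the series, first, only, none or still open, it means among the compounds named here.

Three hydroxamic acids sharing one core have been measured in a functional assay on NUGC-3 cells (Homo sapiens) for inhibition, read by sulforhodamine B assay; a lower number here means a stronger inhibitor of growth, a higher number a weaker inhibitor of growth. Compound 1 `Cc1ccc(CN2CC=C(CCC(=O)NO)C2=O)cc1` gives 4280 nM, compound 2 `O=C(CCC1=CCN(Cc2ccc(F)cc2)C1=O)NO` gives 6060 nM, and compound 3 `O=C(CCC1=CCN(Cc2ccc(Cl)cc2)C1=O)NO` gives 4280 nM. Compound 3 is level with compound 1 and the two together hold the lowest of the three numbers, while a 1.4-fold lower number from compound 2 to compound 3 (0.15 log units; within the scatter). The single-substituent swaps seen so far, a 1.4-fold higher number from compound 1 to compound 2 (0.15 log units; within the scatter) and no change at the digits printed from compound 1 to compound 3 (within the scatter), likewise stay within the scatter. Compound 4 `CC(C)(C)c1ccc(CN2CC=C(CCC(=O)NO)C2=O)cc1` is the next step: tert-butyl in place of chloro on an aromatic carbon. Among the compounds with values here, no measured step introduces a tert-butyl, so the only guide is that every exchange at this place so far left the number essentially unchanged; the expected step is therefore a 1.1-fold higher number from compound 3 to compound 4 (0.02 log units; within the scatter). Compound 4 is estimated at 4500 nM, with a range from 2000 nM to 11000 nM.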

Compound 4, concentration for 50% growth inhibition: 720 nM
Estimate against measurement, compound 4: 6.3-fold (0.80 log units) above; the whole stated range lies above it.
By their numbers in this assay, from the lowest: compound 4; then compounds 1, 3 and 2 (each within the scatter of the next).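

In this assay this place on the aromatic ring now proves able to move the number: tert-butyl in place of chloro gives a 5.9-fold lower number from compound 3 to compound 4 (0.77 log units; beyond the scatter) and in place of methyl gives a 5.9-fold lower number from compound 1 to compound 4 (0.77 log units; beyond the scatter) while in place of fluoro it gives an 8.4-fold lower number from compound 2 to compound 4 (0.93 log units; beyond the scatter) even though methyl, fluoro and chloro stayed within the scatter of one another. Tert-butyl alone stands apart from the other three groups here. No evidence at hand accounts for this difference. From the compounds shown here alone, whether isopropyl, a smaller branched carbon group, would give part of this step remains open. So does what an amine or a carboxylic acid at this place would do.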